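A few compounds are considered here, and "the series" means these few. Any claim that something is new, unique, unknown or untested is made for them only; others in the source may bear on it.

Among the compounds with values here, in an ADME assay on microsomes from liver (Mus musculus) for metabolic stability (on this read-out lower numbers stand for a less stable compound and higher numbers for a more stable compound), compound 2 `C/C(CN(C[C@H]1Cc2ccccc2CN1)[C@H]1CCCc2cccnc21)=C(\F)CN` gives 1%, the lower of the two numbers so far, while compound 1 `C/C(CN)=C(/F)CN(C[C@H]1Cc2ccccc2CN1)[C@H]1CCCc2cccnc21` gives 61%. Compound 3 `N[C@H]1CC[C@@H](N(C[C@H]2Cc3ccccc3CN2)[C@H]2CCCc3cccnc32)CC1` brings a new group on the amine nitrogen: 4-aminocyclohexyl in place of 4-amino-3-fluoro-2-methylbut-2-en-1-yl on an amine nitrogen. Within the data shown here, only one measured step bears on this, the large a number 60 percentage points lower from compound 1 to compound 2 (beyond the scatter), which shows that a change in this chain can shift the number strongly. That step cannot fix the size for a cyclohexyl group, but the number of compound 2, 1%, leaves little room downward. A sizeable rise is therefore expected, a number 29 percentage points higher from compound 2 to compound 3 (beyond the scatter). For compound 3 the estimated value is 30%, with an expected range from 5% to 70%.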

Compound 3, percent of the compound remaining: 56%
Compound 3: middle estimate off by 26 percentage points, on the low side; the measured number falls inside the stated range.
By their numbers in this assay, from the lowest: compound 2; then compounds 3 and 1 (each within the scatter of the next).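

In this assay, the 4-aminocyclohexyl group on the amine nitrogen gives a number 55 percentage points higher from compound 2 to compound 3 (beyond the scatter), so the very low number of compound 2 does not extend to every group in this place. The comparison with the other fluorinated chain shows a number 5 percentage points lower from compound 1 to compound 3 (within the scatter), which means that a ring of carbon only and the 3-(aminomethyl)-2-fluorobut-2-en-1-yl chain cannot be told apart here. Nothing available explains these numbers. The compounds shown leave open what a plain cyclohexyl group without the amine or a piperidine ring would give in this place.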